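The compounds below may be only part of what the source reports. "The series", "measured", "known", "first", "only" and "open" are said of these compounds alone.

Working notes on the series: in a functional assay on T47D cells (Homo sapiens) for inhibition, read by CCK-8 assay, with a stated time of 72 h, tested at 1 uM (on this read-out lower numbers stand for less inhibition of growth and higher numbers for more inhibition of growth at the one concentration tested), compound 1 `CN(C)C(=O)c1cc2cnc(Nc3ccc(NC(=O)C4(C(=O)Nc5ccc(F)cc5)CC4)cc3)nc2n1C1CCCC1` gives 74.7%, compound 2 `CN(C)C(=O)c1cc2cnc(Nc3ccc(NC(=O)C4(C(=O)Nc5ccccc5F)CC4)cc3)nc2n1C1CCCC1` gives 85.2%, and compound 3 `COc1cccc(NC(=O)C2(C(=O)Nc3ccc(Nc4ncc5cc(C(=O)N(C)C)n(C6CCCC6)c5n4)cc3)CC2)c1` gives 56.3%, the lowest of the three numbers. The next structure is compound 4 `CN(C)C(=O)c1cc2cnc(Nc3ccc(NC(=O)C4(C(=O)Nc5ccc(O)cc5)CC4)cc3)nc2n1C1CCCC1`, with 4-hydroxyphenyl in place of 3-methoxyphenyl on an amide-type nitrogen. Three modest steps at this place bear on it: a number 10.5 percentage points higher from compound 1 to compound 2 (beyond the scatter), a number 18.4 percentage points lower from compound 1 to compound 3 (beyond the scatter) and a number 28.9 percentage points lower from compound 2 to compound 3 (beyond the scatter). Within the data shown here, no hydroxyphenyl compound has been measured, so the expectation rests on the drop a number 18.4 percentage points lower from compound 1 to compound 3 (beyond the scatter), with compound 1 as the closest comparison by group name. A modest rise in this assay is expected, estimated as a number 11.7 percentage points higher from compound 3 to compound 4 (beyond the scatter). The estimate for compound 4 is 68%, with an expected range of 48% to 84%.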

Compound 4, percent growth inhibition at one concentration: 91.5%
Compound 4: the middle estimate sits 23.5 percentage points below what was measured; the measured number lies above the stated range.
By their numbers in this assay, from the lowest: compound 3; then compound 1; then compounds 2 and 4 (each within the scatter of the next).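

In this assay, 4-hydroxyphenyl in place of 3-methoxyphenyl on the amide-type nitrogen gives a number 35.2 percentage points higher from compound 3 to compound 4 (beyond the scatter), so this position can carry a large change. Hydroxy in place of fluoro on an aromatic carbon gives a number 16.8 percentage points higher from compound 1 to compound 4 (beyond the scatter), while 4-hydroxyphenyl in place of 2-fluorophenyl gives a number 6.3 percentage points higher from compound 2 to compound 4 (within the scatter), which leaves those two compounds level. Nothing at hand accounts for these steps.

Going by these compounds, compound 3 and compound 4 differ in both the group and its place on the ring, so the share of each in that step remains open. On these data alone, whether an amino group or a carboxylic acid in place of the hydroxy would hold the number also remains open.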